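From 3-fluorophenyl to 3-chlorophenyl: working notes

The source may hold more compounds than are shown below. What is called first, only, known or untested is meant among the compounds shown, and "the series" means these compounds.

Measured in a functional assay on MCF7 cells (Homo sapiens) for antiproliferative activity, read by sulforhodamine B assay, with a stated time of 48 h; on this read-out higher numbers stand for weaker inhibition and lower numbers for stronger inhibition:
- compound 1 `CCc1ccccc1OS(=O)(=O)c1ccc(N2CCN(C)C2=O)cc1`: 26000 nM
- compound 2 `CN1CCN(c2ccc(S(=O)(=O)Oc3cccc(F)c3)cc2)C1=O`: > 100000 nM

Compound 2 stands at > 100000 nM, which is a limit and not a number. The evidence so far reads: the limit of > 100000 nM in this assay, at which 1 of the 2 values shown sits.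

Compound 3 `CN1CCN(c2ccc(S(=O)(=O)Oc3cccc(Cl)c3)cc2)C1=O` carries one change: chloro in place of fluoro on an aromatic carbon. Going by the values given here, the only measured step, an at least 3.8-fold higher number from compound 1 to compound 2 (0.58 log units; beyond the scatter), is a different exchange and ends on a limit, so it gauges size only loosely. In this assay, a small step towards lower numbers is expected, or none beyond the scatter. The estimated change is an at least 1.6-fold lower number from compound 2 to compound 3 (0.22 log units; that floor lies within the scatter). For compound 3 the expected value is 60000 nM, with an estimated range (20000 nM to 150000 nM).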

Compound 3, half-maximal inhibitory concentration: 2200 nM
Beside the measured number, compound 3's estimate is 27-fold (1.44 log units) above it; the measured number lies below the stated range.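

On an aromatic carbon meta to a large group, the identity of the halogen alone moves the result in this assay, where chloro in place of fluoro gives an at least 45-fold lower number from compound 2 to compound 3 (1.65 log units; beyond the scatter) as its step. Compound 2 stands at a limit and not a number, so that step is only a floor: the limit of > 100000 nM in this assay, at which 1 of the 3 values shown sits. The 3-chlorophenyl group also improves on 2-ethylphenyl on the same oxygen, with a 12-fold lower number from compound 1 to compound 3 (1.07 log units; beyond the scatter) as the step.

On these data alone, whether bromo, methyl or methoxy at this position would follow chloro remains open. So does the effect of chloro elsewhere on the ring.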